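The compounds below may be only part of what the source reports. "The series", "measured", "known", "first", "only" and "open" are said of these compounds alone.

In an ADME assay on NIH3T3 cells (Mus musculus) for cytotoxicity, read by fluorescence, with a stated time of 48 h (on this read-out lower numbers stand for stronger inhibition and higher numbers for weaker inhibition), compound 1 (`CCCC(=O)N1CCN(c2ccnc3cc(Cl)ccc23)CC1`) gives 21000 nM. Compound 2 (`O=C(C1CCCC1)N1CCN(c2ccnc3cc(Cl)ccc23)CC1`) gives 21000 nM and compound 3 (`O=C(Nc1ccc(Cl)cc1)N1CCN(c2ccnc3cc(Cl)ccc23)CC1`) gives 21000 nM, which leaves compound 1 level with both at the digits available.

Compound 4 (`O=C(c1ccc(Cl)nc1)N1CCN(c2ccnc3cc(Cl)ccc23)CC1`) has not yet been measured. Its difference from compound 1 is 6-chloropyridin-3-yl in place of propyl on a carbonyl carbon; in words, 6-chloropyridin-3-yl in place of propyl on a carbonyl carbon.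

Three measured steps change the group at that same place: no change at the digits printed from compound 1 to compound 2 (within the scatter), then no change at the digits printed from compound 1 to compound 3 (within the scatter), and finally no change at the digits printed from compound 2 to compound 3 (within the scatter). None of them goes beyond the scatter, whether the entering group is cyclopentyl or (4-chlorophenyl)amino. Among the measured compounds shown here, no measured compound has a ring with a hetero atom at this place, so the new group remains untested and the range is kept wide.

No step beyond the scatter is expected in this assay, in either direction. The estimated step is no change at the digits printed from compound 1 to compound 4 (within the scatter). For compound 4 the expected value is 21000 nM, with an estimated range of 11000 nM to 40000 nM.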

Compound 4, half-maximal inhibitory concentration: 21000 nM
Compound 4: the middle estimate sits on the measured number at the digits printed; the measured number falls inside the stated range.
By their numbers in this assay, from the lowest: compounds 1, 2, 3 and 4 (each within the scatter of the next).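

Among the compounds shown, only compound 4 carries a ring with a hetero atom on the carbonyl carbon, and in this assay the change from propyl to 6-chloropyridin-3-yl gives no change at the digits printed from compound 1 to compound 4 (within the scatter) as its result. Against the two other groups the picture is the same, with no change at the digits printed from compound 2 to compound 4 (within the scatter) for cyclopentyl and no change at the digits printed from compound 3 to compound 4 (within the scatter) for (4-chlorophenyl)amino, so a six-membered aromatic ring with a hetero atom and a hydrogen-bond acceptor joins the groups at this place that show no step beyond the scatter. No supporting measurement accounts for this flat result.

From the compounds shown here alone, whether an amine, a carboxylic acid or a longer chain on this carbonyl carbon would also stay within the scatter remains open. Changes to the shared core also remain open, since all four compounds have it in common.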